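Replacing 2,4-dichlorophenyl with 3-methoxyphenyl: an expected weakening

The compounds below may be only part of what the source reports. "The series", "measured", "known", "first", "only" and "open" are said of these compounds alone.

Of the compounds shown here, three sharing one core have been measured in a functional assay on SMMC-7721 cells (Homo sapiens) for inhibition, read by MTT assay, with a stated time of 48 h (a higher number here means a weaker inhibitor, a lower number a stronger inhibitor), so far. Compound 1 (`Nc1n[nH]c2cccc(-c3cccc(NC(=O)Nc4ccc(F)c(F)c4)c3)c12`) gives 5880 nM there, compound 2 (`Nc1n[nH]c2cccc(-c3cccc(NC(=O)Nc4ccc(Cl)cc4Cl)c3)c12`) gives 1900 nM there, and compound 3 (`Nc1n[nH]c2cccc(-c3cccc(NC(=O)Nc4ccc(Cl)c(C(F)(F)F)c4)c3)c12`) gives 1150 nM there. Compound 2 thus lies within the usual scatter of compound 3, so the two cannot be ranked, while compound 1 shows a clearly higher number than compound 2.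

Compound 4 (`COc1cccc(NC(=O)Nc2cccc(-c3cccc4[nH]nc(N)c34)c2)c1`) has not yet been measured. It carries 3-methoxyphenyl in place of 2,4-dichlorophenyl on an amide-type nitrogen, so the entering group holds no chlorine. For the measured compounds named here, no measured compound carries this group, which leaves no direct precedent. Going by the values given here, the one measured step at this nitrogen is a 3.1-fold lower number from compound 1 to compound 2 (0.49 log units; beyond the scatter) and it is modest. It shows that a swap of this kind can move the number past the scatter. A step of similar modest size is therefore expected in this assay, toward a higher number and a weaker inhibitor. The expected change in this estimate is a 2.4-fold higher number from compound 2 to compound 4 (0.37 log units; beyond the scatter) and it remains uncertain. For compound 4 the estimated value is 4500 nM with an expected range from 1800 nM to 12000 nM in this assay.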

Compound 4, half-maximal inhibitory concentration: 2860 nM
Beside the measured number, compound 4's estimate is 1.6-fold (0.20 log units) above it; the range from low to high includes it.
By their numbers in this assay, from the lowest: compounds 3, 2 and 4 (each within the scatter of the next, the first and the last beyond it); then compound 1.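

In this assay, the 3-methoxyphenyl group on this amide-type nitrogen gives a 1.5-fold higher number from compound 2 to compound 4 (0.18 log units; within the scatter), so a ring with no chlorine and with one hydrogen-bond acceptor cannot be told apart from 2,4-dichlorophenyl at this position. The same group gives a 2.1-fold lower number from compound 1 to compound 4 (0.31 log units; beyond the scatter), which shows that chlorine is not needed for a number clearly lower than that of compound 1, and that compound 1, with its 3,4-difluorophenyl, is the one that stands apart from compound 2 and compound 4. No measured property of these groups is available to account for this result.

All four compounds carry a substituted phenyl ring on this nitrogen, so the compounds shown leave open how a phenyl ring bearing an amine or a carboxylic acid, or a longer chain such as ethoxy in place of the methoxy of compound 4, would read in this assay. They also leave open whether the small differences among compound 2, compound 3 and compound 4 would hold on a different core or in a different cell line.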